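The source may report more compounds than this note shows. Statements on the series, on what has been measured and on what is new or still open speak of the compounds shown alone.

Compound 1 `COc1ccccc1-c1ccc(S(=O)(=O)N2CCC(N3CCC(C)CC3)CC2)cc1`: > 5000 nM (a limit)
Compound 2 `CC1CCN(C2CCN(S(=O)(=O)c3ccc(-c4ccc(Cl)cc4)cc3)CC2)CC1`: > 5000 nM (a limit)

In an ADME assay on HCT-116 cells (Homo sapiens) for cytotoxicity, read by CellTiter-Glo, with a stated time of 72 h (on this read-out higher numbers stand for weaker inhibition and lower numbers for stronger inhibition), compound 2 gives > 5000 nM, which is a limit of the assay and not a number. Compound 1 gives > 5000 nM, which is likewise a limit. Every value available therefore sits at the same limit: the limit of > 5000 nM in this assay, at which 2 of the 2 values shown sit. Compound 2 thus has no numerical position from which to measure a change.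

Compound 3 `CC1CCN(C2CCN(S(=O)(=O)c3ccc(OCc4ccccc4)cc3)CC2)CC1` carries benzyloxy in place of 4-chlorophenyl on an aromatic carbon, para to a large group: benzyloxy in place of 4-chlorophenyl on an aromatic carbon. Within the data shown here, no measured step involves this exchange. The nearest evidence is a change at the same aromatic carbon, a step that the two limits leave unreadable from compound 1 to compound 2, where 4-chlorophenyl replaced 2-methoxyphenyl. That step gives neither a size nor a direction, so no readable change in this assay is expected, and compound 3 will most likely also be reported as a limit.

The expected change is a number no higher from compound 2 to compound 3 (the limit leaves the size open), and this estimate has little support. For compound 3 the estimated value is 5000 nM, with an expected range from 2000 nM to 10000 nM.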

Compound 3, half-maximal inhibitory concentration: > 5000 nM
Compound 3: only a limit was reported (the forecaster's own chance of this, stated with the estimate: 80%); the middle value sits exactly at the limit.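

In this assay compound 3 gives > 5000 nM, which is a limit of the assay and not a number. No step among compound 1, compound 2 and compound 3 can be read, because all three stop at the same point: the limit of > 5000 nM in this assay, at which 3 of the 3 values shown sit.

The compounds shown leave open whether these exchanges on the aromatic carbon change the read-out at all, and in which direction.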